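Compound 2 to compound 3: a step at the limit

The source may report more compounds than this note shows. Statements on the series, on what has been measured and on what is new or still open speak of the compounds shown alone.

Measured in a functional assay on MCF7 cells (Homo sapiens) for antiproliferative activity, read by MTT assay, with a stated time of 72 h; a higher number here means a weaker inhibitor, a lower number a stronger inhibitor
Compound 1 `CC1=CC[C@H]2[C@H](CC[C@]2(C)O)C(C)(C)[C@@H]1CC[C@H]1[C@]2(C)CC[C@H](OC(=O)CCC(=O)O)C(C)(C)O[C@H]2CC[C@@]1(C)O` gives > 50000 nM (a limit)
Compound 2 `CC1=CC[C@H]2[C@H](CC[C@]2(C)O)C(C)(C)[C@@H]1CC[C@H]1[C@]2(C)CC[C@H](OC(=O)c3ccc(C)cc3)C(C)(C)O[C@H]2CC[C@@]1(C)O` gives > 50000 nM (a limit)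

Neither entry is a number. For the measured compounds named here, compound 2 has no value of its own and stands at the limit of > 50000 nM in this assay, at which 2 of the 2 values shown sit, so far. Compound 3 `CC1=CC[C@H]2[C@H](CC[C@]2(C)O)C(C)(C)[C@@H]1CC[C@H]1[C@]2(C)CC[C@H](OC(=O)NS(=O)(=O)c3ccc(C)cc3)C(C)(C)O[C@H]2CC[C@@]1(C)O` carries ((4-methylphenyl)sulfonyl)amino in place of 4-methylphenyl on a carbonyl carbon, and the comparison counts as ((4-methylphenyl)sulfonyl)amino in place of 4-methylphenyl on a carbonyl carbon in full. Going by the values given here, the one measured step at this place is a step that the two limits leave unreadable from compound 1 to compound 2 and it offers no size to carry over. No step beyond the scatter is therefore expected in this assay and no direction can be named. A limit is again the likeliest report, with the series standing at the limit of > 50000 nM in this assay, at which 2 of the 2 values shown sit, for now. Compound 3 is expected to read 50000 nM as the central estimate, with 15000 nM to 70000 nM as the estimated range. The expected change is a number no higher from compound 2 to compound 3 (the limit leaves the size open) in size.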

Compound 3, half-maximal inhibitory concentration: > 50000 nM
Compound 3: no number, only a limit (the forecaster's own chance of this, stated with the estimate: 75%); the middle value sits exactly at the limit.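

In this assay compound 3 gives > 50000 nM, a limit and not a number. No step among compound 1, compound 2 and compound 3 can be read, and the series stands at one value: the limit of > 50000 nM in this assay, at which 3 of the 3 values shown sit.

The compounds shown leave open whether any group on this carbonyl carbon changes the read-out, and in which direction.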